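Swapping the aryl cap of compound 1 for a carbamate-capped pyrrolidine

This account rests on a few compounds, and the source may have more. Where it says the series, first, only, none or still open, it means among the compounds named here.

Compound 1 `O=C(c1ccc(Cl)cc1)N1CCC(NS(=O)(=O)c2cc(S(=O)(=O)c3ccccc3)ccc2C(F)(F)F)CC1` is one of two compounds tested in an assay on isolated protein for displacement of a labelled ligand from secreted frizzled-related protein 1 (Homo sapiens), read by fluorescence polarization, with a stated time of 30 min; on this read-out higher numbers stand for weaker inhibition and lower numbers for stronger inhibition. In this assay compound 1 gives 300 nM, the highest of the two numbers. Its companion compound 2 `O=S(=O)(NC1CCN(S(=O)(=O)c2ccccc2)CC1)c1cc(S(=O)(=O)c2ccccc2)ccc1C(F)(F)F` gives 130 nM in this assay, and the step of a 2.3-fold lower number from compound 1 to compound 2 (0.36 log units; beyond the scatter) came from replacing the group on the amine nitrogen in the ring. Compound 3 `CC(C)(C)OC(=O)N1CC[C@H](C(=O)N2CCC(NS(=O)(=O)c3cc(S(=O)(=O)c4ccccc4)ccc3C(F)(F)F)CC2)C1` instead keeps the carbonyl and changes the group on it: 1-(tert-butoxycarbonyl)pyrrolidin-3-yl in place of 4-chlorophenyl on a carbonyl carbon. Going by the values given here, no measured step changes this part of the molecule, and the one known step at the ring nitrogen concerns a different replacement, so it offers only a loose guide that changes to this cap move the number modestly. The expected step of a 1.5-fold higher number from compound 1 to compound 3 (0.18 log units; within the scatter) is therefore small, with a slightly weaker result judged more likely than a stronger one. Compound 3 is estimated at 450 nM, within a range from 150 nM to 1400 nM.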

Compound 3, half-maximal inhibitory concentration: 70 nM
Beside the measured number, compound 3's estimate is 6.4-fold (0.81 log units) above it, and the stated range ends above it.
By their numbers in this assay, from the lowest: compounds 3 and 2 (each within the scatter of the next); then compound 1.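

On a carbonyl carbon whose other neighbour is the ring's amide-type nitrogen, replacing 4-chlorophenyl with 1-(tert-butoxycarbonyl)pyrrolidin-3-yl gives a 4.3-fold lower number from compound 1 to compound 3 (0.63 log units; beyond the scatter) in this assay. The earlier step replaced the whole cap on the ring nitrogen, carbonyl included; this one keeps the carbonyl and shows that a six-membered aromatic ring of carbon only is not needed on it for a lower number. The larger, non-aromatic group is not only accepted here but gives the lower number, and nothing measured here explains why.

From the compounds shown here alone, this single change alters the ring, the carbamate and the stereocentre together, so their separate contributions stay unknown. A free amine on the pyrrolidine ring, or a simple acetyl group in place of tert-butoxycarbonyl, would show whether the carbamate matters, and the opposite stereoisomer would test the stereocentre.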